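Swapping the indolyl amine in compound 1 for a chlorophenyl

The source may report more compounds than this note shows. Statements on the series, on what has been measured and on what is new or still open speak of the compounds shown alone.

Compound 1 `COc1ccc(-c2nc(C(=O)/C=C\Nc3ccc4[nH]ccc4c3)c3ccccn23)cc1` was tested in a functional assay on BT-474 cells (Homo sapiens) for cytotoxicity, read by MTT assay, with a stated time of 48 h (on this read-out lower numbers stand for stronger inhibition and higher numbers for weaker inhibition), where compound 1 gives 13000 nM, the lower of the two numbers recorded. Its nearest neighbour, compound 2 `O=C(/C=C\Nc1cnc2ccccc2c1)c1nc(-c2ccccc2)n2ccccc12`, gives 19700 nM in this assay, a gap within the scatter, so the two stand level. Compound 3 `COc1ccc(-c2nc(C(=O)/C=C\Nc3ccc(Cl)cc3)c3ccccn23)cc1` has not yet been measured; it differs from compound 1 by 4-chlorophenyl in place of 1H-indol-5-yl on an amine nitrogen. Among the compounds with values here, no measured pair shows this change, so a step of modest size, most likely toward a higher number or none beyond the scatter, is expected as a 1.5-fold higher number from compound 1 to compound 3 (0.19 log units; within the scatter). Compound 3 is estimated at 20000 nM, with a range from 8000 nM to 50000 nM.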

Compound 3, half-maximal inhibitory concentration: 37300 nM
For compound 3 the middle estimate is 1.9-fold (0.27 log units) below the measured one; the measured number falls inside the stated range.
By their numbers in this assay, from the lowest: compounds 1, 2 and 3 (each within the scatter of the next, the first and the last beyond it).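

In this assay, the group on the amine nitrogen proves able to move the number: 4-chlorophenyl in place of 1H-indol-5-yl brings a 2.9-fold higher number from compound 1 to compound 3 (0.46 log units; beyond the scatter). This is the first step beyond the scatter among these compounds, and it runs toward weaker inhibition, though it rests on this single pair. It also removes the hydrogen-bond donor of 1H-indol-5-yl, along with one of the two rings, so the pair cannot separate these differences.

From the compounds shown here alone, whether a 4-aminophenyl or 4-carboxyphenyl group on this nitrogen would match compound 1 remains open. No measurement on hand accounts for the rise in the number.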